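A few compounds are considered here, and "the series" means these few. Any claim that something is new, unique, unknown or untested is made for them only; others in the source may bear on it.

Of the compounds shown here, two have so far been measured in a functional assay on P388 cells (Mus musculus) for inhibition, tested at 10 uM; a lower number here means a weaker effect, a higher number a stronger effect of the compound at the concentration tested. Compound 1 `COc1ccc2c(c1)c(-c1cc(C(F)(F)F)c(C#N)c(-c3cn(S(=O)(=O)c4ccc(C)cc4)c4ccc(OC)cc34)n1)cn2S(=O)(=O)c1ccc(C)cc1` gives 3.5% in this assay, the lower of the two numbers. Compound 2 `Cc1ccc(S(=O)(=O)n2cc(-c3cc(C(F)(F)F)cc(-c4cn(S(=O)(=O)c5ccc(C)cc5)c5ccccc45)n3)c3ccccc32)cc1` gives 23.5%, a number that sits beyond the scatter above compound 1. Compound 2 differs from compound 1 in more than one place, so nothing is taken from that pair beyond what the two values show.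

Compound 3 `COc1ccc2c(c1)c(-c1cc(C(F)(F)F)cc(-c3cn(S(=O)(=O)c4ccc(C)cc4)c4ccc(OC)cc34)n1)cn2S(=O)(=O)c1ccc(C)cc1` has not yet been measured in this assay. It differs from compound 1 in a single place: hydrogen in place of cyano on an aromatic carbon. For the measured compounds named here, no measured pair shows what removing the cyano does here, so the size of the step is open. Compound 2, with 23.5%, also lacks a cyano on the shared core, which hints weakly upward, but a step within the scatter in either direction remains as plausible. The expected step for compound 3 is a number 6.5 percentage points higher from compound 1 to compound 3 (within the scatter), a modest rise at most. The estimate for compound 3 in this assay is 10%, with a range from 0% to 28%.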

Compound 3, a percentage reported as inhibition, at one concentration (the size of the read-out at that concentration, not a potency): 5%
Compound 3: middle estimate off by 5 percentage points, on the high side, and the stated range covers the measured number.
By their numbers in this assay, from the lowest: compounds 1 and 3 (each within the scatter of the next); then compound 2.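

In this assay, for the compounds shown here, the one single-place pair gives a number 1.5 percentage points higher from compound 1 to compound 3 (within the scatter), so losing the cyano, which sits ortho to a trifluoromethyl group, leaves the read-out within the scatter. At the concentration tested, this read-out therefore does not tell cyano and hydrogen apart at this position on the core of compound 1, and the earlier pair of compounds, which differ in more than one place, could not show this. Nothing at hand bears on why the two numbers lie so close together.

As far as these compounds go, it remains open whether this position would respond to other groups, such as an amine, a carboxylic acid or a longer chain, since a single pair with two low numbers says nothing about substituents other than cyano and hydrogen. Also open, from the compounds shown here alone, is whether adding a cyano at the same place on the core of compound 2, which gives 23.5%, would produce a step of similar size there.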